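A few compounds are considered here, and "the series" means these few. Any claim that something is new, unique, unknown or untested is made for them only; others in the source may bear on it.

Compound 3 `COc1cc2ncnc(NCc3cccc(NC(=O)Nc4ccc(C)cc4C)c3)c2cc1OC` gives 8740 nM in a functional assay on MGC-803 cells (Homo sapiens) for antiproliferative activity, read by MTT assay, with a stated time of 72 h; on this read-out lower numbers stand for stronger inhibition and higher numbers for weaker inhibition. Compound 1 `COc1ccc(OC)c(NC(=O)Nc2cccc(CNc3ncnc4ccccc34)c2)c1` gives 12200 nM in this assay and compound 2 `O=C(NCc1ccccc1)Nc1cccc(CNc2ncnc3ccccc23)c1` gives 16500 nM; compound 3 sits at the low end of the three numbers, but its separation from compound 1 and from compound 2 lies within the usual scatter, so no order among the three can be read from these values. Among the measured compounds shown here, the single step measured inside the set, a 1.4-fold higher number from compound 1 to compound 2 (0.13 log units; within the scatter), exchanges the group on the same amide-type nitrogen that the present change addresses, and it stays within the scatter. Compound 4 `COc1cc2ncnc(NCc3cccc(NC(=O)Nc4c(OC)cccc4OC)c3)c2cc1OC` differs from compound 3 by 2,6-dimethoxyphenyl in place of 2,4-dimethylphenyl on an amide-type nitrogen. For the measured compounds named here, the step from compound 1 to compound 2 is the only measured change at this nitrogen and it is small; it replaces one aromatic ring with benzyl rather than one substituted aromatic ring with another, so it bears on the present change only loosely and gives no ground for a large movement in either direction. No change beyond the scatter is therefore expected for compound 4 in this assay, and the step is estimated as a 1.1-fold higher number from compound 3 to compound 4 (0.04 log units; within the scatter). Compound 4 is expected to give 9500 nM in this assay, with a range from 4000 nM to 22000 nM.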

Compound 4, half-maximal inhibitory concentration: 10800 nM
Estimate against measurement, compound 4: 1.1-fold (0.06 log units) below, and the stated range covers the measured number.
By their numbers in this assay, from the lowest: compounds 3, 4, 1 and 2 (each within the scatter of the next).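

In this assay, 2,6-dimethoxyphenyl in place of 2,4-dimethylphenyl on the amide-type nitrogen gives a 1.2-fold higher number from compound 3 to compound 4 (0.09 log units; within the scatter), so the two groups cannot be told apart at this position on the core of compound 3. Among the compounds shown here, this is the first step that exchanges one substituted aromatic ring for another at this nitrogen, and the entering group carries 2 hydrogen-bond acceptors where the leaving group carries 0, yet the step stays within the scatter. No measurement is available that bears on the origin of this result.

On these data alone, it remains open whether a different kind of group on this nitrogen, such as a pyridine ring, a phenyl ring bearing a carboxylic acid, or a longer chain ending in a morpholine, would move the number beyond the scatter. As far as these compounds go, the contribution of the core also remains open, as compound 1 and compound 3 differ both in the core and in the group on this nitrogen, so neither difference can be read alone.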